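Amidine series: a carboxypentyl-to-phenoxyethyl exchange on the amide

The source may hold more compounds than are shown below. What is called first, only, known or untested is meant among the compounds shown, and "the series" means these compounds.

For the measured compounds named here, the two measured members are compound 1, `CCCCC(NC(=O)C(CC(=O)O)NC(=O)CCCOc1ccc(C(=N)N)cc1)C(=O)O`, and compound 2, `CC[C@H](C)[C@H](NC(=O)[C@H](CC(=O)O)NC(=O)CCCOc1ccc(C(=N)N)cc1)C(=O)O`. In a physicochemical assay for lipophilicity (on this read-out higher numbers stand for higher lipophilicity and lower numbers for lower lipophilicity), compound 1 gives 1.58, and compound 2 gives 1.47. Compound 1 holds the higher of the two numbers, but the gap to compound 2 lies within the scatter of the method, so the two cannot be ranked against each other on this assay.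

Compound 3, `CC(C)c1ccc(OCCNC(=O)C(CC(=O)O)NC(=O)CCCOc2ccc(C(=N)N)cc2)cc1`, is not yet measured. Relative to compound 1 the change is 2-(4-isopropylphenoxy)ethyl in place of 1-carboxypentyl on an amide-type nitrogen. Going by the values given here, no measured pair shows a step of this kind, so the direction and size of the step must be judged from the structures alone, not from any recorded difference.

The step is expected to be upward and clearly beyond the scatter, since an acid-bearing chain is replaced by a longer chain carrying an aromatic ring and no donor. The estimated step from compound 1 to compound 3 in this assay is a number 1.22 log units higher from compound 1 to compound 3 (beyond the scatter). For compound 3 the expected value in this assay is 2.8, with a range from 2 to 3.6.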

Compound 3, partition coefficient: 2.21
Compound 3: the middle estimate sits 0.59 log units above what was measured; measured number inside the range.
By their numbers in this assay, from the lowest: compounds 2 and 1 (each within the scatter of the next); then compound 3.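

The amide-type nitrogen whose other neighbour is the carbonyl carbon now has its first recorded step beyond the scatter: in this assay, 2-(4-isopropylphenoxy)ethyl in place of 1-carboxypentyl gives a number 0.63 log units higher from compound 1 to compound 3 (beyond the scatter). This single exchange changes several things at once: 8 heavy atoms with 1 hydrogen-bond donor and no ring leave, while 12 heavy atoms with 0 hydrogen-bond donors and one six-membered aromatic ring of carbon only enter. Nothing available assigns the step to any one of these differences.

The compounds shown leave open how much of the step goes with the loss of the carboxylic acid and how much with the entering aromatic ring, and a plain pentyl group or an unsubstituted 2-phenoxyethyl group on the same nitrogen would separate the two contributions. Also open, from the compounds shown here alone, is the part played by the isopropyl group on the ring, which a comparison with a methyl group or a hydrogen in its place would address, and whether a shorter or longer chain between the ether oxygen and the amide-type nitrogen would alter the step.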